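This account rests on a few compounds, and the source may have more. Where it says the series, first, only, none or still open, it means among the compounds named here.

Values in a toxicity assay on HepG2 cells (Homo sapiens) for inhibition, read by resazurin assay, with a stated time of 24 h; on this read-out lower numbers stand for higher toxicity in this test and higher numbers for lower toxicity in this test (each one a limit of the assay, not a number):
- compound 1 `COc1ccc(CNC(=O)c2ncc([N+](=O)[O-])n2C)cc1` gives > 100000 nM
- compound 2 `Cn1c([N+](=O)[O-])cnc1C(=O)N1CCCC1` gives > 100000 nM
- compound 3 `O=C(c1ncc([N+](=O)[O-])[nH]1)N1CCCC1` gives > 100000 nM

Compound 3 has no readable number in this assay and stands at > 100000 nM, which is a limit. The series as a whole shows the same picture, with the limit of > 100000 nM in this assay, at which 3 of the 3 values shown sit.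

Compound 4 `O=C(NCCO)c1ncc([N+](=O)[O-])[nH]1` differs from compound 3 by (2-hydroxyethyl)amino in place of pyrrolidin-1-yl on a carbonyl carbon. In words, (2-hydroxyethyl)amino stands in place of pyrrolidin-1-yl on a carbonyl carbon.

Going by the values given here, the only measured step is a step that the two limits leave unreadable from compound 2 to compound 3, and it concerns a different place, so it offers no size to carry over. Among the compounds with values here, no measured step covers this change. The expectation therefore rests on the three limits alone, and no step beyond the scatter is expected in this assay, in either direction.

The estimated step is a number no higher from compound 3 to compound 4 (the limit leaves the size open).

For compound 4 the expected value is 100000 nM, with an estimated range from 50000 nM to 200000 nM, and a report as a limit is the likely outcome.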

Compound 4, half-maximal cytotoxic concentration: > 100000 nM
Compound 4: no number, only a limit; the forecaster's own chance of this, stated with the estimate: 90%; the middle value sits exactly at the limit.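

In this assay compound 4 gives > 100000 nM, a limit, and no step can be read between compound 3 and compound 4. The series stays flat at one ceiling: the limit of > 100000 nM in this assay, at which 4 of the 4 values shown sit.

The compounds shown leave open what concentration, if any, would produce a half-maximal cytotoxic effect for any of them.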